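The source may report more compounds than this note shows. Statements on the series, on what has been measured and on what is new or still open speak of the compounds shown alone.

Compound 1 `CCCC(CC(=O)N1CCC(Cn2c(C)nc3cnccc32)CC1)c1ccccc1`: 0.0079 mg/kg
Compound 2 `Cc1nc2cnccc2n1CC1CCN(C(=O)CC(O)(c2ccccc2)c2ccccc2)CC1`: 0.013 mg/kg

Both values come from a functional assay on the whole organism (arterial blood) with Rattus norvegicus as the target; on this read-out higher numbers stand for an effect only at larger amounts of compound and lower numbers for an effect already at smaller amounts. Compound 2 gives 0.013 mg/kg and compound 1 gives 0.0079 mg/kg, and these two values lie within the usual scatter of each other. Compound 2 therefore cannot be separated from compound 1 on these numbers.

Compound 3 `Cc1nc2cnccc2n1CC1CCN(C(=O)CC(O)(c2ccccc2)C(F)(F)F)CC1` has not yet been measured. It carries trifluoromethyl in place of phenyl on a saturated chain carbon bound to an aromatic carbon, an oxygen on a saturated carbon and a saturated chain carbon. Among the compounds with values here, no measured pair shows this exchange, so the expectation is a loose one. A moderate move towards larger doses is expected, beyond the scatter, with the estimated step of a 3.8-fold higher number from compound 2 to compound 3 (0.59 log units; beyond the scatter). For compound 3 the estimated value is 0.05 mg/kg, with an expected range from 0.012 mg/kg to 0.25 mg/kg.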

Compound 3, dose for 50% inhibition: 0.013 mg/kg
Beside the measured number, compound 3's estimate is 3.8-fold (0.59 log units) above it; the range from low to high includes it.
By their numbers in this assay, from the lowest: compounds 1, 2 and 3 (each within the scatter of the next).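

In this assay, putting trifluoromethyl in place of phenyl on this saturated chain carbon gives no change at the digits printed from compound 2 to compound 3 (within the scatter). Within the data shown here, the earlier compounds contained no pair differing in one place, so this is the first direct reading at this position: here, one of the two phenyl groups of compound 2 can give way to a group with no ring and fewer heavy atoms without a change that can be told from the scatter. The data offer no explanation for why the read-out holds across this exchange.

From the compounds shown here alone, whether a methyl, a cyclopropyl ring or an amine at the same carbon would also stay within the scatter of compound 2 remains open. So does the contribution of the remaining phenyl and of the hydroxyl group on that carbon.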